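This account rests on a few compounds, and the source may have more. Where it says the series, first, only, none or still open, it means among the compounds named here.

Measured compounds:
compound 1, `CC1=NC(C)=C([N+](=O)[O-])C(c2cccc(C)n2)/C1=C(/O)OC(C)C`, gives 25100 nM in a functional assay (muscle tissue) with Cavia porcellus as the target; a lower number here means a stronger inhibitor, a higher number a weaker inhibitor
compound 2, `CC1=NC(C)=C([N+](=O)[O-])C(c2ncccc2C)/C1=C(/O)OC(C)C`, gives 2820 nM in this assay
compound 3, `CC1=NC(C)=C([N+](=O)[O-])C(c2ccccn2)/C1=C(/O)OCCc1ccccc1`, gives 639 nM in this assay

Among the three, compound 3 stands at the lowest number: compound 2 is the nearest, and compound 1 the furthest, both beyond the scatter. Compound 4, `CC1=NC(C)=C([N+](=O)[O-])C(c2cccc(Cl)n2)/C1=C(/O)OCCc1ccccc1`, is not yet measured. It differs from compound 3 by one change, (chloro in place of hydrogen on an aromatic carbon), so that the pyridin-2-yl of compound 3 becomes a 6-chloropyridin-2-yl.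

Among the measured compounds shown here, only one measured step touches this ring: an 8.9-fold lower number from compound 1 to compound 2 (0.95 log units; beyond the scatter). That step moved a methyl away from the carbon next to the ring nitrogen, and the number fell. Compound 4 puts a chloro on that same carbon, which is the reverse kind of change, though with a different group; compound 1 and compound 3 differ in two places at once, so their values alone cannot separate the two effects. On this basis a weaker inhibitor than compound 3 is expected, with a step of a 4.7-fold higher number from compound 3 to compound 4 (0.67 log units; beyond the scatter) in this assay, but with wide uncertainty. Compound 4 is estimated at 3000 nM, in the range 800 nM to 12000 nM.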

Compound 4, half-maximal inhibitory concentration: 1510 nM
For compound 4 the middle estimate is 2.0-fold (0.30 log units) above the measured one, and the stated range covers the measured number.
By their numbers in this assay, from the lowest: compound 3; then compounds 4 and 2 (each within the scatter of the next); then compound 1.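

In this assay, chloro in place of hydrogen on an aromatic carbon next to the ring nitrogen gives a 2.4-fold higher number from compound 3 to compound 4 (0.37 log units; beyond the scatter), a modest weakening that lies beyond the scatter. Among the compounds shown here, this is the first direct comparison of a substituent on this carbon with hydrogen: the earlier step, an 8.9-fold lower number from compound 1 to compound 2 (0.95 log units; beyond the scatter), compared two placements of a methyl on the ring and so had no unsubstituted partner, whereas here the 6-chloropyridin-2-yl compound can be read against the pyridin-2-yl compound with the rest of the structure unchanged. Nothing available gives a measured reason for the size or direction of this step.

As far as these compounds go, since only chloro is compared with hydrogen on this carbon, it remains open whether the weakening is particular to chloro or would also appear with fluoro, methoxy, an amine or a methyl in the same structural setting. The compounds shown also leave open how chloro would behave on the other carbons of the ring, and whether the same step would be seen with a different ester group.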